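A few compounds are considered here, and "the series" means these few. Any claim that something is new, unique, unknown or untested is made for them only; others in the source may bear on it.

Measured so far in a functional assay on CAKI-1 cells (Homo sapiens) for inhibition; a lower number here means a stronger inhibitor of growth, a higher number a weaker inhibitor of growth
- compound 1 `COc1cc(/C=C/C(=O)c2cccc(-n3cc(-c4ccc(Cl)cc4)[nH]c3=O)c2)cc(OC)c1OC` gives "not active" (no number reported) with no number reported
- compound 2 `COc1cc(/C=C/C(=O)c2cccc(-n3cc(-c4ccccc4)[nH]c3=O)c2)ccc1O` gives 2190 nM as the only number

Compound 2 therefore has no numerical comparator. Compound 3 `COc1cc(/C=C/C(=O)c2cccc(-n3cc(-c4ccc(Cl)cc4)[nH]c3=O)c2)ccc1O` differs from compound 2 by chloro in place of hydrogen on an aromatic carbon, with chloro in place of hydrogen on an aromatic carbon, turning phenyl into 4-chlorophenyl. Among the compounds with values here, no measured pair isolates this change. Compound 1 also carries 4-chlorophenyl and gives "not active" (no number reported) as its result, though it differs elsewhere too, so only a modest weakening is expected. The expected change, a 1.3-fold higher number from compound 2 to compound 3 (0.11 log units; within the scatter), is small and may not exceed the scatter. Compound 3 is estimated at 2800 nM, within an expected range of 900 nM to 9000 nM in this assay.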

Compound 3, concentration for 50% growth inhibition: 2640 nM
The estimate for compound 3 lay 1.1-fold (0.03 log units) above the measured number; the measured number falls inside the stated range.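

In this assay, chloro in place of hydrogen on an aromatic carbon, para to a large group, gives a 1.2-fold higher number from compound 2 to compound 3 (0.08 log units; within the scatter), so phenyl to 4-chlorophenyl leaves the number within the scatter at this position. Compound 3, carrying 4-chlorophenyl, still gives a numerical result of 2640 nM. No measurement at hand offers an explanation for this result.

As far as these compounds go, whether an amine or a carboxylic acid in place of chloro would move the number beyond the scatter remains open. This single pair also cannot show whether the change behaves alike elsewhere in the series.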